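The source may report more compounds than this note shows. Statements on the series, on what has been measured and on what is new or still open speak of the compounds shown alone.

In a functional assay on HeLa cells (Homo sapiens) for cytotoxicity, read by XTT assay, with a stated time of 72 h (a lower number here means a stronger inhibitor, a higher number a weaker inhibitor), three compounds have been measured so far. Compound 1 `CCCCCCCCCCCCCCCCCCc1c(O)cc(O)c(C(C)=O)c1O` gives 26000 nM. Compound 2 `CC(=O)c1c(O)cc(O)c2c1OC(C)(C)CC2` is reported only as a limit of the assay, > 100000 nM. Compound 3 `C=C1CC[C@H]2C(C)(C)CCC[C@]2(C)[C@H]1CC/C(C)=C/COc1cc(O)c2c(=O)c(O)c(-c3ccc(O)cc3)oc2c1` likewise reaches only a limit of the assay, > 100000 nM, so no number is known for it. Compound 3 thus stands at the edge of what the assay can report, a position it shares with one other entry, as the limit of > 100000 nM in this assay, at which 2 of the 3 values shown sit, shows.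

Compound 4 `C=C1CC[C@H]2C(C)(C)CCC[C@]2(C)[C@H]1CC/C(C)=C/COc1cc(O)c2c(=O)c(O)c(-c3ccc(OC)cc3)oc2c1` has not yet been measured in this assay. It differs from compound 3 in a single place: methyl in place of hydrogen on an oxygen on an aromatic ring. For the measured compounds named here, no step between two measured compounds is available to show how large an effect such a change has had elsewhere in this set, so the expectation rests on compound 3 alone. Given that compound 3 shows only a limit, the expected step is a step that the limit leaves unreadable from compound 3 to compound 4, that is, nothing beyond the usual scatter. Compound 4 is therefore estimated at 150000 nM, within a range from 60000 nM to 400000 nM, with a good chance that the assay again reports only a limit rather than a number.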

Compound 4, half-maximal inhibitory concentration: > 100000 nM
Compound 4 ended at the assay's limit; the forecaster's own chance of this, stated with the estimate: 75%; the middle value does not contradict the limit.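

Compound 3 and compound 4 both end at a limit rather than a number in this assay, so the change from hydroxy to methoxy has no readable size: the limit of > 100000 nM in this assay, at which 3 of the 4 values shown sit. The compounds shown leave open whether this change alters the effect on these cells at all.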